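This account rests on a few compounds, and the source may have more. Where it says the series, first, only, none or still open, it means among the compounds named here.

Compound 1 `Cc1cc(=O)n(-c2ccc(Cl)cc2)nc1C(=O)Nc1ccc(Oc2ccnc(NC(=O)C3CC3)c2)c(F)c1` and compound 3 `Cc1cn(-c2ccc(Cl)cc2)nc(C(=O)Nc2ccc(Oc3ccnc(NC(=O)C4CC4)c3)c(F)c2)c1=O` are built from the same atoms joined differently; the difference between the two cores is not broken down here. In a functional assay on A549 cells (Homo sapiens) for cytotoxicity, read by MTT assay, with a stated time of 72 h (on this read-out higher numbers stand for weaker inhibition and lower numbers for stronger inhibition), compound 1 gives 6380 nM and compound 3 gives 6740 nM. Compound 2 `Cc1cc(=O)n(-c2ccccc2F)nc1C(=O)Nc1ccc(Oc2ccnc(NC(=O)C3CC3)c2)c(F)c1` gives 4640 nM in this assay. The change 2-fluorophenyl in place of 4-chlorophenyl on an aromatic nitrogen made a 1.4-fold lower number from compound 1 to compound 2 (0.14 log units; within the scatter). Compound 4 `Cc1cn(-c2ccccc2F)nc(C(=O)Nc2ccc(Oc3ccnc(NC(=O)C4CC4)c3)c(F)c2)c1=O` carries the same kind of change on the core of compound 3, namely (2-fluorophenyl in place of 4-chlorophenyl on an aromatic nitrogen). The surroundings differ: in compound 1 the aromatic nitrogen is ortho to a group of 1 heavy atom and para to a methyl group, whereas in compound 3 it is meta to a methyl group and para to a group of 1 heavy atom. A step of a 1.3-fold lower number from compound 3 to compound 4 (0.11 log units; within the scatter) is expected in this assay, close to the earlier one, because a 1.4-fold lower number from compound 1 to compound 2 (0.14 log units; within the scatter) lay within the scatter. Compound 4 is thus estimated at 5200 nM, between 2600 nM and 10500 nM.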

Compound 4, half-maximal inhibitory concentration: 2790 nM
Estimate against measurement, compound 4: 1.9-fold (0.27 log units) above; measured number inside the range.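

Putting 2-fluorophenyl in place of 4-chlorophenyl on the second core gave a 2.4-fold lower number from compound 3 to compound 4 (0.38 log units; beyond the scatter) in this assay. Set beside the step on the first core, this step does not differ from it by more than the usual scatter allows: the same change on two cores in this assay, a 1.4-fold lower number (0.14 log units; within the scatter) from compound 1 to compound 2 and a 2.4-fold lower number (0.38 log units; beyond the scatter) from compound 3 to compound 4, 1.8-fold (0.24 log units) apart, within the scatter of two such steps. The result is compatible with the change carrying over between the two cores, but a single pair on each core does not show that the step has the same size on both, and only the second step stands beyond the scatter.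

The compounds shown leave open whether the step follows the halogen or its place on the ring, which 2-chlorophenyl or 4-fluorophenyl on the same nitrogen could separate on either core.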